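A few compounds are considered here, and "the series" means these few. Any claim that something is new, unique, unknown or untested is made for them only; others in the source may bear on it.

In a functional assay on SW480 cells (Homo sapiens) for antiproliferative activity, read by MTT assay, with a stated time of 72 h (a lower number here means a stronger inhibitor, a higher number a weaker inhibitor), a set of close relatives of one scaffold was compared. Compound 3, `O=c1c(Cl)c(CSC(=S)N2CCCC2)oc2ccccc12`, gives 1400 nM. Compound 1, `O=c1c(Cl)c(CSC(=S)N2CCCCC2)oc2ccccc12`, carries a single change from it, (piperidin-1-yl in place of pyrrolidin-1-yl on a thiocarbonyl carbon), and gives 690 nM. That one swap produced a step of a 2.0-fold lower number from compound 3 to compound 1 (0.31 log units; beyond the scatter), so the larger ring made the compound a somewhat stronger inhibitor.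

Compound 2, `COc1ccc2occ(CSC(=S)N3CCCC3)c(=O)c2c1`, has a different core; how it differs from the core of compound 3 is not broken down here. In this assay compound 2 gives 4800 nM, a weaker result than either compound 3 or compound 1.

Compound 4, `COc1ccc2occ(CSC(=S)N3CCCCC3)c(=O)c2c1`, is not yet measured. It stands to compound 2 exactly as compound 1 stands to compound 3: the change is piperidin-1-yl in place of pyrrolidin-1-yl on a thiocarbonyl carbon, at the same place as before, so it is the same change. Among the compounds with values here, the expectation is that compound 4 will be a stronger inhibitor than compound 2 by about the same margin, an estimated step of a 2.0-fold lower number from compound 2 to compound 4 (0.30 log units; within the scatter), because the single earlier example of this swap gave a 2.0-fold lower number from compound 3 to compound 1 (0.31 log units; beyond the scatter). On that basis compound 4 is estimated at 2400 nM, likely between 1200 nM and 4800 nM.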

Compound 4, half-maximal inhibitory concentration: 6700 nM
The estimate for compound 4 lay 2.8-fold (0.45 log units) below the measured number, and the stated range ends below it.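

Placed on the other core, piperidin-1-yl in place of pyrrolidin-1-yl gave a 1.4-fold higher number from compound 2 to compound 4 (0.14 log units; within the scatter) in this assay, so the gain seen on the chlorine-bearing core did not appear here. The result of this swap therefore depends on the core it is made on, at least for these two cores: the same change on two cores in this assay, a 2.0-fold lower number (0.31 log units; beyond the scatter) from compound 3 to compound 1 and a 1.4-fold higher number (0.14 log units; within the scatter) from compound 2 to compound 4, 2.8-fold (0.45 log units) apart, beyond the scatter of two such steps. This rests on a single pair on each core, and it shows neither which difference between the cores matters nor how the swap would behave on any other core.

The compounds shown leave open whether the chlorine or the methoxy group goes with the different outcome, and a core carrying only one of the two would separate them. They also leave open how another amine on a thiocarbonyl carbon, such as morpholin-4-yl or an open-chain diethylamino group, would behave on either core.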